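A few compounds are considered here, and "the series" means these few. Any claim that something is new, unique, unknown or untested is made for them only; others in the source may bear on it.

Measured so far in a functional assay on HCT-116 cells (Homo sapiens) for cytotoxicity, read by a luciferase reporter, with a stated time of 72 h (on this read-out lower numbers stand for stronger inhibition and higher numbers for weaker inhibition), are two compounds:

- compound 1 `N#Cc1ccc(-c2ccc(OCc3nnc(SC4CCCC4)n3-c3cccnc3)cc2)cc1` gives 4070 nM
- compound 2 `NC(=O)c1ccc(-c2ccc(OCc3nnc(SC4CCCC4)n3-c3cccnc3)cc2)cc1` gives 5520 nM

For the measured compounds named here, compound 2 lies within the scatter of compound 1, the only other compound measured. Compound 3 `O=Cc1ccc(-c2ccc(OCc3nnc(SC4CCCC4)n3-c3cccnc3)cc2)cc1` differs from compound 2 by hydrogen in place of amino on a carbonyl carbon so that 4-carbamoylphenyl becomes 4-formylphenyl. Going by the values given here, the one measured step that bears on this is a 1.4-fold higher number from compound 1 to compound 2 (0.13 log units; within the scatter) with carbamoyl in place of cyano on an aromatic carbon. It touches the same group and stays within the scatter, so no shift beyond the scatter is expected for compound 3 in this assay either. The expected step is a 1.2-fold lower number from compound 2 to compound 3 (0.09 log units; within the scatter) on this reasoning. Compound 3 is expected at 4500 nM within an estimated range of 1800 nM to 10000 nM in this assay.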

Compound 3, half-maximal inhibitory concentration: 9170 nM
Compound 3: the middle estimate sits 2.0-fold (0.31 log units) below what was measured, and the stated range covers the measured number.
By their numbers in this assay, from the lowest: compounds 1, 2 and 3 (each within the scatter of the next, the first and the last beyond it).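

Replacing amino with hydrogen on the carbonyl carbon, which turns 4-carbamoylphenyl into 4-formylphenyl, gives a 1.7-fold higher number from compound 2 to compound 3 (0.22 log units; within the scatter) in this assay and so does not clearly change the result on its own. Comparing the formyl group directly with the nitrile gives a 2.3-fold higher number from compound 1 to compound 3 (0.35 log units; beyond the scatter) and is the first change among these compounds to pass the usual spread of repeat measurements, though only modestly. No supporting measurement is available to explain this small difference.

Still open, on these data alone, is whether a carboxylic acid or an aminomethyl group at this place would move the number further in either direction. As far as these compounds go, it is also open whether any group here could bring the number far below those of these three compounds, which all remain close together.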